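Aziridinylquinone side chains: a chain shortened on compound 2

This account rests on a few compounds, and the source may have more. Where it says the series, first, only, none or still open, it means among the compounds named here.

Three compounds of the series have numbers. In a functional assay on L1210 cells (Mus musculus), with a stated time of 12 days (a lower number here means a less potent compound, a higher number a more potent compound, by a factor of ten per unit of this negative logarithm), compound 1 `CN(C)C(=O)OCCC1=C(N2CC2)C(=O)C(CCOC(=O)N(C)C)=C(N2CC2)C1=O` gives 5.16, compound 2 `CCC(OC)C1=C(N2CC2)C(=O)C(C)=C(N2CC2)C1=O` gives 5.68, and compound 3 `CCC1=C(N2CC2)C(=O)C(C(COC(N)=O)OC)=C(N2CC2)C1=O` gives 6.16. Compound 2 stands second highest of the three, sitting between compound 1 and compound 3, and both of its gaps lie beyond the scatter.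

Compound 4 `COCCC1=C(N2CC2)C(=O)C(C)=C(N2CC2)C1=O` is still unmeasured. It differs from compound 2 in one place: 2-methoxyethyl in place of 1-methoxypropyl on a double-bonded ring carbon.

Within the data shown here, no step between measured compounds isolates a change of this kind, so the size of the step is uncertain. For compound 4 the expected value in this assay is 5.6, within a range of 5 to 6.2. The expected step of a number 0.08 log units lower from compound 2 to compound 4 (within the scatter) is estimated to fall within the scatter.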

Compound 4, logarithm of the reciprocal of the active concentration, log(1/C): 5.57
Estimate against measurement, compound 4: 0.03 log units above, and the stated range covers the measured number.
By their numbers in this assay, from the lowest: compound 1; then compounds 4 and 2 (each within the scatter of the next); then compound 3.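

In this assay, among these compounds, 2-methoxyethyl in place of 1-methoxypropyl on a double-bonded ring carbon gives a number 0.11 log units lower from compound 2 to compound 4 (within the scatter) and is the first single-place step. The two chains are therefore not told apart by this read-out, at least with a methyl group three ring bonds away. No further measurement bears on this pair of chains.

Still open, going by these compounds, is whether an amine or a carboxylic acid at the end of this chain would give a step beyond the scatter. The same question holds for a chain longer than 1-methoxypropyl.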